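Lengthening a chain and losing a hydroxy group

The source may report more compounds than this note shows. Statements on the series, on what has been measured and on what is new or still open speak of the compounds shown alone.

Measured compounds:
- compound 1, `CCCCCCCCCCCCCCCCc1c(C)c(N(C)C)nc(C)c1O`: 83%
- compound 2, `Cc1c(N(C)C)nc(CCCCCCCCCCO)c(O)c1C`: 36%
- compound 3, `CCCCCCCCCCCCCCCCc1c(C)c(N2CCC2)nc(C)c1O`: 72%

All three were tested in a functional assay on cells (Lymphocyte, Homo sapiens) for inhibition, read by flow cytometry, using a membrane potential dye, with a stated time of 16 h, tested at 250 nM; on this read-out higher numbers stand for a stronger effect at the one concentration tested and lower numbers for a weaker effect. Compound 2 stands lowest of the three numbers, beyond the scatter from both others: compound 3 sits well above it, and compound 1 higher still. For the measured compounds named here, the only step measured between two compounds that differ in one place is a number 11 percentage points lower from compound 1 to compound 3 (beyond the scatter); it concerns the amine group, not the chain, so it does not bear on the change considered here.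

Compound 4, `CCCCCCCCCCCCCCCCCCCc1nc(N(C)C)c(C)c(C)c1O`, is not yet measured. It differs from compound 2 in one place: nonyl in place of hydroxy on a saturated chain carbon, ten or more bonds along the chain from an aromatic carbon. Going by the values given here, no measured pair shows this change, so the expectation rests on the broader picture: compound 1 and compound 3, which carry a long chain without a hydroxy group, give the two higher numbers in this assay, while compound 2, with the hydroxy-ended chain, gives the lowest. On that basis compound 4 is expected to move upward, with an estimated step of a number 34 percentage points higher from compound 2 to compound 4 (beyond the scatter). The estimate for compound 4 in this assay is 70%, within a range from 45% to 90%.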

Compound 4, a percentage reported as activity, at one concentration (the size of the read-out at that concentration, not a potency): 44%
For compound 4 the middle estimate is 26 percentage points above the measured one, and the stated range ends above it.
By their numbers in this assay, from the lowest: compounds 2 and 4 (each within the scatter of the next); then compound 3; then compound 1.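

In this assay, putting nonyl in place of hydroxy on a saturated chain carbon, ten or more bonds along the chain from an aromatic carbon, gives a number 8 percentage points higher from compound 2 to compound 4 (within the scatter). At this place, then, a chain ending in hydroxy and a much longer chain with no hydroxy cannot be told apart at the one concentration tested, and compound 1 and compound 3 cannot settle the matter, since each differs from compound 4 in more than one place. No separate measurement is available to explain this result.

The compounds shown leave open whether a carboxylic acid or an amine in place of hydroxy at the end of the chain would give a number beyond the scatter from compound 2. They also leave open whether an intermediate chain, such as pentyl in place of hydroxy at this same place, would read any differently from compound 2 and compound 4, and whether a full concentration series would separate these two compounds.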